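The source may report more compounds than this note shows. Statements on the series, on what has been measured and on what is new or still open speak of the compounds shown alone.

Measured so far:
Compound 1, `COc1ccc(N2C[C@@H](C)N[C@@H](C)C2)cc1NS(=O)(=O)c1ccc(-c2ccccn2)s1` — 1.1
Compound 2, `COc1ccc(N2C[C@@H](C)N[C@@H](C)C2)cc1NS(=O)(=O)c1ccc(-c2cc(Cl)ccc2F)cc1` — 1

Both compounds were tested in a functional assay for agonist activity at growth hormone secretagogue receptor type 1 (Homo sapiens), read by FLIPR; a higher number here means a larger maximal response, a lower number a smaller maximal response. Compound 2 gives 1 there, and compound 1 gives 1.1; these two values lie within the usual scatter of each other, so neither can be called the larger, and both reach the full response of the reference agonist.

Compound 3, `COc1ccc(N2C[C@@H](C)N[C@@H](C)C2)cc1NS(=O)(=O)c1ccc(-c2ccc(C)o2)cc1`, has not yet been measured. It differs from compound 2 in one place: 5-methylfuran-2-yl in place of 5-chloro-2-fluorophenyl on an aromatic carbon. Within the data shown here, no step between measured compounds is available for this change, so the expectation rests on the two values alone. Compound 3 is expected to reach about 1, with a likely range from 0.85 to 1.15, because compound 2 gives 1 and compound 1 gives 1.1 with a different group in the same place. The expected step is no change at the digits printed from compound 2 to compound 3 (within the scatter), which is no change beyond the scatter.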

Compound 3, intrinsic activity: the largest response reached, as a fraction of the reference agonist's: 1
Compound 3: middle estimate and measured number agree at the digits printed; the range from low to high includes it.
By their numbers in this assay, from the lowest: compounds 2, 3 and 1 (each within the scatter of the next).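

In this assay, 5-methylfuran-2-yl in place of 5-chloro-2-fluorophenyl gives no change at the digits printed from compound 2 to compound 3 (within the scatter), the first step available for a change at this one position, on an aromatic carbon para to a large group. It shows that the maximal response holds across quite different groups here: a five-membered aromatic ring with 1 hetero atom and 6 heavy atoms takes the place of a six-membered aromatic ring of carbon only, in a group of 8 heavy atoms, and gains 1 hydrogen-bond acceptor. Nothing available explains why the response holds across this swap.

Going by these compounds, whether the response would also hold with an amine, a carboxylic acid or a longer alkyl chain at this position remains open. The compounds shown also leave open whether changes elsewhere on the shared core would alter the response.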